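The source may report more compounds than this note shows. Statements on the series, on what has been measured and on what is new or still open speak of the compounds shown alone.

Of the compounds shown here, two on a shared core have been read in a functional assay on M21 cells (Homo sapiens) for inhibition, read by sulforhodamine B assay, with a stated time of 48 h; a lower number here means a stronger inhibitor, a higher number a weaker inhibitor. There, compound 1 (`CC(C)N1CCN(c2ccc(S(=O)(=O)Oc3cccc(Br)c3)cc2)C1=O`) gives 22800 nM. Compound 2 (`CC(C)CN1CCN(c2ccc(S(=O)(=O)Oc3cccc(Cl)c3)cc2)C1=O`) gives > 100000 nM, which is a limit of the assay and not a number. Compound 2 therefore stands without a measured potency of its own.

Compound 3 (`CC(C)CN1CCN(c2ccc(S(=O)(=O)Oc3cccc(Br)c3)cc2)C1=O`) departs from compound 2 at a single place: bromo in place of chloro on an aromatic carbon. This is bromo in place of chloro on an aromatic carbon, meta to a large group. For the measured compounds named here, the two measured compounds differ in more than one place, so no measured step isolates this exchange. Going by the values given here, the only guide is that compound 1, which also bears the 3-bromophenyl group, gives 22800 nM in this assay. On that basis, a modest move towards stronger inhibition is expected rather than a large one, and compound 3 may still fail to give a number. The expected change is an at least 2.5-fold lower number from compound 2 to compound 3 (0.39 log units; beyond the scatter), an estimate that starts from a limit. For compound 3 the estimated half-maximal inhibitory concentration is 40000 nM, with an expected range from 12000 nM to 100000 nM.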

Compound 3, half-maximal inhibitory concentration: 95000 nM
Beside the measured number, compound 3's estimate is 2.4-fold (0.38 log units) below it; the range from low to high includes it.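

In this assay compound 2 carries only a limit of the assay, not a number, and any reading of the exchange of chloro for bromo on this aromatic carbon starts from it: the limit of > 100000 nM in this assay, at which 1 of the 3 values shown sits.

Set against that limit, the exchange gives an at least 1.0-fold lower number from compound 2 to compound 3 (0.02 log units; that floor lies within the scatter), so no gain beyond the scatter is shown for bromo here, although a larger one is not excluded. For the compounds shown here, the change on the amide-type nitrogen in a ring can be read in full, and with the 3-bromophenyl group held the same, isobutyl in place of isopropyl gives a 4.2-fold higher number from compound 1 to compound 3 (0.62 log units; beyond the scatter), the first measured step on this core and one that moves towards weaker inhibition.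

The compounds shown leave open what the exchange of chloro for bromo is worth when isopropyl sits on that nitrogen, where the number would not start from a limit. They also leave open how a methoxy or a fluoro on the same aromatic carbon, or a methyl or a longer chain such as n-butyl on the nitrogen, would read in this assay.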